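A few compounds are considered here, and "the series" means these few. Any claim that something is new, unique, unknown or untested is made for them only; others in the source may bear on it.

Compound 1 `CC(C)(C)Cc1csc(N)c1C(=O)c1cccc(C(F)(F)F)c1`: 1%
Compound 2 `CC(C)(C)Cc1c(Br)sc(N)c1C(=O)c1cccc(Cl)c1`: 1%

Of the compounds shown here, two sharing the same core have been measured in an assay on CHO cells for displacement of a labelled ligand from adenosine receptor A1 (Homo sapiens), read by scintillation counting, tested at 10 uM; on this read-out higher numbers stand for more inhibition at the one concentration tested (going by the name of the read-out) and lower numbers for less inhibition. Compound 1 gives 1% in this assay. Going by the values given here, compound 2 gives 1% in this assay, which is level with compound 1 at the digits reported; no step between the two has been computed, so only the bare values can be compared, and they show no difference beyond the usual scatter. Both compounds sit at the bottom of the scale.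

The next compound, compound 3 `CC(C)(C)Cc1c(Br)sc(N)c1C(=O)c1cccc(C(F)(F)F)c1`, has not yet been measured. Relative to compound 2 the change is trifluoromethyl in place of chloro on an aromatic carbon. Compound 1 already carries this trifluoromethyl group on the same aromatic ring and gives the same reading as compound 2, so there is no sign in the data that this exchange moves the read-out. The step from compound 2 to compound 3 is expected to be none beyond the scatter, with compound 3 estimated to remain at the floor: a number 1 percentage points higher from compound 2 to compound 3 (within the scatter). For compound 3 the expected reading in this assay is 2%, with a range from -8% to 12%.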

Compound 3, a percentage reported as inhibition, at one concentration (the size of the read-out at that concentration, not a potency): 1%
For compound 3 the middle estimate is 1 percentage points above the measured one, and the stated range covers the measured number.
By their numbers in this assay, from the lowest: compounds 1, 2 and 3 (each within the scatter of the next).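

Compounds 1 and 2 differ in two places, so their equal readings could not speak to either change alone; compound 3 now allows each change to be read separately in this assay. Trifluoromethyl in place of chloro on an aromatic carbon, meta to a large group, gives no change at the digits printed from compound 2 to compound 3 (within the scatter), and bromo in place of hydrogen on an aromatic carbon gives no change at the digits printed from compound 1 to compound 3 (within the scatter). Neither single change lifts the reading from the bottom of the scale, and no measurement shown offers an explanation for this.

The compounds shown leave open whether any other group at these two places would raise the reading in this assay, for instance a methoxy group or a carboxylic acid on the six-membered ring, or an amine or a methyl group in place of the bromo. Going by these compounds alone, they also leave open whether these two exchanges would still make no difference on a compound that gives a higher reading, as all the values here lie together at the bottom of the scale.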